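Methoxy addition on the benzyl ring: compound 4 outlook

The source may hold more compounds than are shown below. What is called first, only, known or untested is meant among the compounds shown, and "the series" means these compounds.

Measured compounds:
- compound 1, `COc1cc(Cn2cc(CNC(=O)c3cn(-c4ccccc4)nc3-c3ccc(F)cc3)nn2)cc(OC)c1`, 190 nM
- compound 2, `COc1cc(Cn2cc(CNC(=O)c3cn(-c4ccccc4)nc3-c3ccc(F)cc3)nn2)cc(OC)c1OC`, 5200 nM
- compound 3, `COc1ccc(Cn2cc(CNC(=O)c3cn(-c4ccccc4)nc3-c3ccc(OC)cc3)nn2)cc1`, 2500 nM

In a functional assay on MIA PaCa-2 cells (Homo sapiens) for antiproliferative activity, read by sulforhodamine B assay, with a stated time of 48 h (a lower number here means a stronger inhibitor of growth, a higher number a weaker inhibitor of growth), compound 1 gives 190 nM. Compound 2 differs from compound 1 by methoxy in place of hydrogen on an aromatic carbon, and the step of a 27-fold higher number from compound 1 to compound 2 (1.44 log units; beyond the scatter) shows how much ground is lost with that single addition. Compound 3 gives 2500 nM in this assay and stands second highest of the three numbers; the difference between its core and the core of compound 1 is not broken down here.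

Compound 4, `COc1ccc(-c2nn(-c3ccccc3)cc2C(=O)NCc2cn(Cc3ccc(OC)c(OC)c3)nn2)cc1`, is not yet measured. It differs from compound 3 by methoxy in place of hydrogen on an aromatic carbon. This is the same kind of change as from compound 1 to compound 2, but not the same: in compound 2 the entering methoxy sits ortho to two methoxy groups and para to a large group, whereas in compound 4 it sits ortho to a methoxy group and meta to a large group, on the same kind of carbon-only six-membered aromatic ring.

Among the compounds with values here, the step from compound 3 to compound 4 is expected to run in the same direction as the earlier one, toward a higher number, but to be smaller, estimated at a 2.8-fold higher number from compound 3 to compound 4 (0.45 log units; beyond the scatter), because the only precedent is a 27-fold higher number from compound 1 to compound 2 (1.44 log units; beyond the scatter) and the surroundings of the added group are not the same. Compound 4 is therefore expected to give about 7000 nM in this assay, with a range from 2000 nM to 30000 nM.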

Compound 4, concentration for 50% growth inhibition: 16300 nM
Compound 4: middle estimate off by 2.3-fold (0.37 log units), on the low side, within the range that was stated.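

In this assay, methoxy in place of hydrogen on an aromatic carbon, here 4-methoxybenzyl to 3,4-dimethoxybenzyl, again weakens growth inhibition, with a 6.5-fold higher number from compound 3 to compound 4 (0.81 log units; beyond the scatter). The direction is shared by the two available pairs, but the size of the step does not carry over from one core to the other: the same change on two cores in this assay, a 27-fold higher number (1.44 log units; beyond the scatter) from compound 1 to compound 2 and a 6.5-fold higher number (0.81 log units; beyond the scatter) from compound 3 to compound 4, 4.2-fold (0.62 log units) apart, beyond the scatter of two such steps. These two pairs do not show what sets the size, as they differ both in the rest of the molecule and in the surroundings of the entering methoxy, and they give no basis for predicting the size of the step on a further core.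

Open, from the compounds shown here alone, is how a 3,4-dimethoxybenzyl group behaves on the core of compound 1, a comparison that would separate the effect of the core from that of the methoxy pattern on the benzyl ring. Also open, going by these compounds, is whether the loss is specific to methoxy or also follows from other groups at the same place on the 4-methoxybenzyl ring, such as hydroxyl, fluorine or a longer chain like ethoxy.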